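The source may hold more compounds than are shown below. What is called first, only, known or untested is meant among the compounds shown, and "the series" means these compounds.

Working notes on the series

The series is assessed in a functional assay on CWR22R cells (Homo sapiens) for antiproliferative activity, read by propidium iodide staining, with a stated time of 96 h; a lower number here means a stronger inhibitor, a higher number a weaker inhibitor. Compound 1 `CC(O)(CSc1cccc(C(F)(F)F)c1)C(=O)Nc1ccc(S(F)(F)(F)(F)F)cc1` gives 23400 nM. Compound 2 `CC(O)(CSc1ccccc1C(F)(F)F)C(=O)Nc1ccc(S(F)(F)(F)(F)F)cc1` gives 13200 nM. The two share a core and differ only by 2-(trifluoromethyl)phenyl in place of 3-(trifluoromethyl)phenyl on a sulfur; this change makes a 1.8-fold lower number from compound 1 to compound 2 (0.25 log units; within the scatter). Compound 3 `CC(O)(CSc1cccc(C(F)(F)F)c1)C(=O)Nc1cccc(S(F)(F)(F)(F)F)c1` gives 12900 nM, and its value lies within the scatter of both compound 1 and compound 2. The difference between the core of compound 1 and the core of compound 3 is not broken down here.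

Compound 4 `CC(O)(CSc1ccccc1C(F)(F)F)C(=O)Nc1cccc(S(F)(F)(F)(F)F)c1` has not yet been run in this assay . Among the measured compounds shown here, it differs from compound 3 by 2-(trifluoromethyl)phenyl in place of 3-(trifluoromethyl)phenyl on a sulfur, the same kind of change as the one from compound 1 to compound 2, made at a sulfur with the same surroundings. Given the measured step of a 1.8-fold lower number from compound 1 to compound 2 (0.25 log units; within the scatter), compound 4 is expected to sit near compound 3, with a step of about a 1.4-fold lower number from compound 3 to compound 4 (0.16 log units; within the scatter), since that one earlier instance stays within the scatter and rests on a single pair. The estimate for compound 4 is therefore 9000 nM, expected to fall between 4000 nM and 22000 nM.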

Compound 4, half-maximal inhibitory concentration: 13200 nM
For compound 4 the middle estimate is 1.5-fold (0.17 log units) below the measured one; measured number inside the range.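

In this assay, 2-(trifluoromethyl)phenyl in place of 3-(trifluoromethyl)phenyl on a sulfur gives a 1.0-fold higher number from compound 3 to compound 4 (0.01 log units; within the scatter). The two instances of this change can be set side by side: the same change on two cores in this assay, a 1.8-fold lower number (0.25 log units; within the scatter) from compound 1 to compound 2 and a 1.0-fold higher number (0.01 log units; within the scatter) from compound 3 to compound 4, 1.8-fold (0.26 log units) apart, within the scatter of two such steps. On the two cores shown, the change therefore behaves alike as far as this assay can resolve, but both steps lie within the scatter, so this shows only that no effect of the change can be told apart on either core; it does not show that the change has a real effect of a fixed size, nor that the same would hold on any further core.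

The compounds shown leave open whether a nitrile or an amine in place of the trifluoromethyl group on the ring carried by the sulfur would give a step beyond the scatter. They also leave open what a sulfone in place of the sulfur, or a carboxylic acid in place of the pentafluorosulfanyl group, would do to the number.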